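The source may report more compounds than this note shows. Statements on the series, on what has been measured and on what is new or still open speak of the compounds shown alone.

Working notes on the dodecyl-tetrazole acetamide series, measured in an assay on liver for inhibition of sterol O-acyltransferase 1 (Rattus norvegicus), using microsomes; on this read-out lower numbers stand for stronger inhibition and higher numbers for weaker inhibition.

Three compounds have numbers. Compound 1 `CCCCCCCCCCCCn1nnc(C(C(=O)Nc2c(C)nn(C)c2C)c2ccccc2)n1` gives 13 nM. Compound 3 `CCCCCCCCCCCCn1nnc(CC(=O)Nc2c(C(C)C)cccc2C(C)C)n1` gives 5 nM. Compound 2 `CCCCCCCCCCCCn1nnc(C(C(=O)Nc2c(OC)cc(OC)cc2OC)c2ccc(N(C)C)cc2)n1` gives 659 nM, the highest of the three numbers; the nearest is compound 1 and the furthest is compound 3, and both gaps are well beyond the scatter. Among the measured compounds shown here, compound 2 is the only member carrying both a trimethoxyphenyl anilide and an aryl group on the carbon between the tetrazole and the carbonyl, so the two features cannot be separated on the present numbers.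

Compound 4 `CCCCCCCCCCCCn1nnc(CC(=O)Nc2c(OC)cc(OC)cc2OC)n1` is not yet measured. It differs from compound 2 in one place: hydrogen in place of 4-(dimethylamino)phenyl on a saturated chain carbon bound to an aromatic carbon and a carbonyl carbon. For the measured compounds named here, no step between measured compounds matches this change. Compound 3, which also carries only hydrogen at that position, gives 5 nM, while compound 1, which carries a phenyl there, gives 13 nM; both sit far below compound 2, so the substituent at this carbon is not the sole driver.

For compound 4 the number is expected to fall, with the step from compound 2 to compound 4 estimated at a 4.4-fold lower number from compound 2 to compound 4 (0.64 log units; beyond the scatter), although the trimethoxyphenyl anilide has no comparator and the estimate is wide. Compound 4 is expected at 150 nM, in the range 30 nM to 700 nM.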

Compound 4, half-maximal inhibitory concentration: 24 nM
Beside the measured number, compound 4's estimate is 6.3-fold (0.80 log units) above it; measured number outside the range, below it.
By their numbers in this assay, from the lowest: compound 3; then compounds 1 and 4 (each within the scatter of the next); then compound 2.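

In this assay, among the compounds shown here, with the trimethoxyphenyl anilide held fixed, the first direct reading at this carbon is a 27-fold lower number from compound 2 to compound 4 (1.44 log units; beyond the scatter), a large step that exceeds anything the indirect comparisons could establish. This separates the two features that compound 2 combined: the trimethoxyphenyl anilide does not by itself keep the number high, as compound 4 gives 24 nM, and the high number of compound 2 goes with the 4-(dimethylamino)phenyl at this position on this anilide. No measurement at hand accounts for the size of this step, so the change can be described but not explained.

The compounds shown leave open whether the aromatic ring or the dimethylamino group of the departing substituent carries the step, which a plain phenyl, a 4-methoxyphenyl or a methyl at this carbon on the trimethoxyphenyl anilide would help to settle. They also leave open whether a step of this size recurs on other anilides, or with an octyl chain in place of the dodecyl chain.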